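Cytotoxicity notes: fluoro to hydrogen on the aryl ring

This account rests on a few compounds, and the source may have more. Where it says the series, first, only, none or still open, it means among the compounds named here.

Compound 1 `CS(=O)(=O)c1ccc(C(=O)N2CCC(C(=O)N3CCN(c4ccc(F)cc4)CC3)CC2)cc1[N+](=O)[O-]` stands only as a limit in an ADME assay on HepG2 cells (Homo sapiens) for cytotoxicity, read by CellTiter-Glo and ATP content, with a stated time of 72 h; a lower number here means that less compound is needed, a higher number that more compound is needed for the effect: it gives > 27000 nM, a limit of the assay rather than a number. Compound 2 `CC(C)N(C(=O)CNC(=O)c1ccc(S(C)(=O)=O)c([N+](=O)[O-])c1)C(C)C` gives > 27000 nM, again a limit. Compound 3 `CS(=O)(=O)c1ccc(C(=O)N2CCC(C(=O)N(Cc3ccccc3)Cc3ccccc3)CC2)cc1[N+](=O)[O-]` gives > 27000 nM, also a limit. Going by the values given here, all three values therefore sit at the limit of > 27000 nM in this assay, at which 3 of the 3 values shown sit, and no step between measured compounds can be sized. Compound 4 `CS(=O)(=O)c1ccc(C(=O)N2CCC(C(=O)N3CCN(c4ccccc4)CC3)CC2)cc1[N+](=O)[O-]` differs from compound 1 by hydrogen in place of fluoro on an aromatic carbon. Among the compounds with values here, with no measured step to lean on, no change beyond the scatter is expected in this assay, and compound 4 is expected to return a limit as well, an expectation that rests on (the limit of > 27000 nM in this assay, at which 3 of the 3 values shown sit). The estimate for compound 4 is 27000 nM, with a range of 13500 nM to 54000 nM. The expected step is a number no higher from compound 1 to compound 4 (the limit leaves the size open).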

Compound 4, half-maximal effective concentration: > 27000 nM
Compound 4: only a limit was reported; the forecaster's own chance of this, stated with the estimate: 85%; the middle value lies on the limit itself.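

Compound 1 and compound 4 both stand only as limits, so the change from 4-fluorophenyl to phenyl gives no readable step. The compounds shown leave open whether any member of this series would return a number rather than a limit.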